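Swapping the 3-carbamoylphenyl group of compound 3

The compounds below may be only part of what the source reports. "The series", "measured", "known", "first", "only" and "open" are said of these compounds alone.

Measured in an ADME assay (liver) for metabolic stability, with Liver microsome (Rattus norvegicus) as the target, using microsomes and NADPH, with a stated time of 30 min, tested at 1 uM; on this read-out lower numbers stand for slow clearance and higher numbers for fast clearance:
compound 1 `Nc1ccc(S(=O)(=O)N2CCN(c3ncc(C(O)(C(F)(F)F)C(F)(F)F)cc3C3CC3)CC2)cn1` gives 27 mL.min-1.g-1
compound 2 `CC(C)(O)C#Cc1cc(C(O)(C(F)(F)F)C(F)(F)F)cnc1N1CCN(S(=O)(=O)c2ccc(N)nc2)CC1` gives 16 mL.min-1.g-1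
compound 3 `NC(=O)c1cccc(-c2cc(C(O)(C(F)(F)F)C(F)(F)F)cnc2N2CCN(S(=O)(=O)c3ccc(N)nc3)CC2)c1` gives 63 mL.min-1.g-1

Compound 3 stands highest of the three, and both of its gaps lie beyond the scatter. Compound 4 `COc1cncc(-c2cc(C(O)(C(F)(F)F)C(F)(F)F)cnc2N2CCN(S(=O)(=O)c3ccc(N)nc3)CC2)c1` carries 5-methoxypyridin-3-yl in place of 3-carbamoylphenyl on an aromatic carbon and is still unmeasured. Three measured steps change this same carbon: a 2.3-fold higher number from compound 1 to compound 3 (0.37 log units; beyond the scatter) and a 3.9-fold higher number from compound 2 to compound 3 (0.60 log units; beyond the scatter) are modest, while a 1.7-fold lower number from compound 1 to compound 2 (0.23 log units; within the scatter) stays within the scatter. None of them brings in 5-methoxypyridin-3-yl, so they offer only a guide to size. Expected in this assay is a 1.4-fold lower number from compound 3 to compound 4 (0.15 log units; within the scatter) and so nothing beyond the scatter. Compound 4 is estimated at 45 mL.min-1.g-1 (range 20 mL.min-1.g-1 to 100 mL.min-1.g-1).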

Compound 4, intrinsic clearance in microsomes: 58 mL.min-1.g-1
Compound 4: middle estimate off by 1.3-fold (0.11 log units), on the low side; the range from low to high includes it.
By their numbers in this assay, from the lowest: compounds 2 and 1 (each within the scatter of the next); then compounds 4 and 3 (each within the scatter of the next).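

In this assay, a 1.1-fold lower number from compound 3 to compound 4 (0.04 log units; within the scatter), so 3-carbamoylphenyl and 5-methoxypyridin-3-yl read alike at this carbon, although the entering group has a ring nitrogen and no hydrogen-bond donor. A second aromatic group with a different substituent now sits at the high end of the series, with a 3.6-fold higher number from compound 2 to compound 4 (0.56 log units; beyond the scatter) and a 2.1-fold higher number from compound 1 to compound 4 (0.33 log units; beyond the scatter). No supporting measurement accounts for this. As far as these compounds go, whether an unsubstituted phenyl group would read the same remains open. So does the outcome with a carboxylic acid or an aminomethyl group on that aromatic ring.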